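The source may hold more compounds than are shown below. What is called first, only, known or untested is meant among the compounds shown, and "the series" means these compounds.

Of the compounds shown here, three that share one core have been tested in a functional assay on MIA PaCa-2 cells (Homo sapiens) for inhibition, read by MTT assay, with a stated time of 3 days (on this read-out higher numbers stand for weaker inhibition and lower numbers for stronger inhibition), so far. Compound 1 `O=C([C@@H]1CCCN(S(=O)(=O)c2ccc(S(=O)(=O)N3CC[C@@H](O)C3)cc2)C1)N1CCC(F)(F)CC1` gave only a limit of this assay, > 3000 nM, and not a number. Compound 2 `CCN(CC)S(=O)(=O)c1ccc(S(=O)(=O)N2CCC[C@@H](C(=O)N3CCC(OC)CC3)C2)cc1` also gave only a limit, > 10000 nM. Compound 3 `CCN(CC)S(=O)(=O)c1ccc(S(=O)(=O)N2CCC[C@@H](C(=O)N3CCOCC3)C2)cc1` stands at the same limit of this assay, > 10000 nM, so its inhibition is known only as a limit and not as a number. The change from compound 2 to compound 3 is accordingly a step that the two limits leave unreadable from compound 2 to compound 3; the two limits hide whatever size it has. Within the data shown here, two of the three values sit at the limit of > 10000 nM in this assay, at which 2 of the 3 values shown sit, and one at the limit of > 3000 nM in this assay, at which 1 of the 3 values shown sits, so none of the measured steps has a readable size.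

Compound 4 `CCN(CC)S(=O)(=O)c1ccc(S(=O)(=O)N2CCC[C@@H](C(=O)N3CCC(C(F)(F)F)CC3)C2)cc1` differs from compound 3 in one place: 4-(trifluoromethyl)piperidin-1-yl in place of morpholin-4-yl on a carbonyl carbon. Among the measured compounds shown here, no measured step bears directly on this change, and the one step recorded between compounds that differ in one place cannot be read. For the measured compounds named here, the only guide is that every value so far is a limit of weak inhibition. In this assay compound 4 is therefore expected to show no step beyond the scatter, a number no higher from compound 3 to compound 4 (the limit leaves the size open). Compound 4 is estimated at 10000 nM, within 3000 nM to 30000 nM, and most likely to be reported once more only as a limit.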

Compound 4, half-maximal inhibitory concentration: > 10000 nM
Compound 4: a limit, no number; the forecaster's own chance of this, stated with the estimate: 70%; the middle value lies on the limit itself.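

In this assay compound 4 gives > 10000 nM, a limit and not a number. Compound 2 and compound 3 also stand only as limits, so the steps from either of them to compound 4 cannot be read. The compounds shown leave open whether any group on the carbonyl carbon changes inhibition at all.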